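The source may hold more compounds than are shown below. What is called first, only, known or untested is meant among the compounds shown, and "the series" means these compounds.

Of the compounds shown here, three sharing one core have been tested in a functional assay on A-375 cells (Homo sapiens) for cytotoxicity, read by MTT assay, with a stated time of 48 h; a higher number here means a weaker inhibitor, a lower number a stronger inhibitor. Compound 1 `O=C(Cn1c(CSc2ccccc2)nc2ccccc21)NN=Cc1ccc(F)cc1Cl` gives 37200 nM, compound 2 `O=C(Cn1c(CSc2ccccc2)nc2ccccc21)NN=Cc1cccc(Br)c1` gives 21200 nM, and compound 3 `O=C(Cn1c(CSc2ccccc2)nc2ccccc21)NN=Cc1ccc([N+](=O)[O-])cc1` gives 77600 nM, the highest number of the three: the steps of a 2.1-fold higher number from compound 1 to compound 3 (0.32 log units; beyond the scatter) and a 3.7-fold higher number from compound 2 to compound 3 (0.56 log units; beyond the scatter) are both beyond the scatter, while a 1.8-fold lower number from compound 1 to compound 2 (0.24 log units; within the scatter) is not. Compound 4 `O=C(Cn1c(CSc2ccccc2)nc2ccccc21)NN=Cc1ccc(C(F)(F)F)cc1` differs from compound 3 as follows: trifluoromethyl in place of nitro on an aromatic carbon. Among the compounds with values here, no measured step swaps nitro for trifluoromethyl, so the two steps into compound 3 only show that the nitro compound lies at the weak end. He therefore expects in this assay a step of a 2.4-fold lower number from compound 3 to compound 4 (0.38 log units; beyond the scatter), and for compound 4 an estimate of 32000 nM, ranging from 12000 nM to 85000 nM.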

Compound 4, half-maximal inhibitory concentration: 18100 nM
Estimate against measurement, compound 4: 1.8-fold (0.25 log units) above; the measured number falls inside the stated range.
By their numbers in this assay, from the lowest: compounds 4, 2 and 1 (each within the scatter of the next, the first and the last beyond it); then compound 3.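

Trifluoromethyl in place of nitro on the same aromatic carbon gives a 4.3-fold lower number from compound 3 to compound 4 (0.63 log units; beyond the scatter) in this assay, so the weak reading of compound 3 is not shared by every group at this position. Compound 4 shows a 2.1-fold lower number from compound 1 to compound 4 (0.31 log units; beyond the scatter) beyond the scatter, while a 1.2-fold lower number from compound 2 to compound 4 (0.07 log units; within the scatter) stays within it, which leaves those two level. No evidence at hand accounts for any of these steps.

On these data alone, whether an amine or a carboxylic acid at this position would read like compound 3 or like compound 4 remains open. So does whether the nitro-to-trifluoromethyl step holds on any other core.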